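This account rests on a few compounds, and the source may have more. Where it says the series, first, only, none or still open, it means among the compounds named here.

Compound 3, `CCn1c(C(=O)On2nnc3ccccc32)ccc1C(CC)(CC)c1ccc(C#CC(O)(CC)CC)c(C)c1`, carries on its carbonyl carbon a group of 10 heavy atoms with one five-membered aromatic ring with 3 hetero atoms and one six-membered aromatic ring of carbon only. In an assay on cells for agonist activity at vitamin D3 receptor (Homo sapiens), read by microscopy (a lower number here means that less compound is needed, a higher number that more compound is needed for the effect), compound 3 gives > 50 nM, and this is a limit of the assay rather than a number. Its two neighbours in the series share the same core. Compound 1, `CCn1c(C(=O)NCCC(=O)OC)ccc1C(CC)(CC)c1ccc(C#CC(O)(CC)CC)c(C)c1`, gives in this assay > 50 nM, again a limit. Compound 2, `CCN(CC)CCCNC(=O)c1ccc(C(CC)(CC)c2ccc(C#CC(O)(CC)CC)c(C)c2)n1CC`, gives in this assay 68.9 nM. The steps that touch the same carbonyl carbon are a step that the two limits leave unreadable from compound 1 to compound 3 and a step that the limit leaves unreadable from compound 2 to compound 3, and the remaining step is a step that the limit leaves unreadable from compound 1 to compound 2; none of the three has a readable size, which follows from the limit of > 50 nM in this assay, at which 2 of the 3 values shown sit.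

Compound 4, `CCCCC(=O)c1ccc(C(CC)(CC)c2ccc(C#CC(O)(CC)CC)c(C)c2)n1CC`, differs from compound 3 by a group of 4 heavy atoms (4 carbon; no ring) in place of a group of 10 heavy atoms (6 carbon, 3 nitrogen, 1 oxygen; one five-membered aromatic ring with 3 hetero atoms, one six-membered aromatic ring of carbon only), on a carbonyl carbon. Within the data shown here, the measured steps at this position give no direction and no size, so the expectation for the step that the limit leaves unreadable from compound 3 to compound 4 rests only on the observation that the one numeric value in the set, that of compound 2, sits close to the limit. Compound 4 is therefore estimated at 80 nM, with a range from 25 nM to 300 nM, and a sizeable chance that this assay again returns only a limit.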

Compound 4, half-maximal effective concentration: > 50 nM
Compound 4 was reported as a limit (the forecaster's own chance of this, stated with the estimate: 55%); the middle value lies beyond the limit too.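

In this assay compound 4 gives > 50 nM, which is a limit and not a number. Its steps from compound 1, compound 2 and compound 3 therefore cannot be read, because of this: the limit of > 50 nM in this assay, at which 3 of the 4 values shown sit. The compounds shown leave open how far the group on the carbonyl carbon changes the concentration needed, and only compound 2 has a numeric value.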